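Aryl urea series: bromo to iodo on the aromatic carbon

The source may report more compounds than this note shows. Statements on the series, on what has been measured and on what is new or still open speak of the compounds shown alone.

In an ADME assay on the whole organism with Oryza sativa as the target, tested at 10 uM (a higher number here means a weaker effect of the compound at the concentration tested, a lower number a stronger effect), the three measured compounds stand as follows.
Compound 1 `CCc1cccc(NC(=O)N[C@@H](C)c2ccccc2)c1`: 86%
Compound 2 `CCOC(=O)c1cccc(NC(=O)N[C@@H](C)c2ccccc2)c1`: 96%
Compound 3 `C[C@H](NC(=O)Nc1cccc(Br)c1)c1ccccc1`: 99%

Compound 3 carries the largest of the three numbers. Its nearest neighbour is compound 2, the step being a number 3 percentage points higher from compound 2 to compound 3 (within the scatter); the furthest is compound 1, with a number 13 percentage points higher from compound 1 to compound 3 (beyond the scatter). Between the two lower numbers the step from the ethyl compound to the ester is a number 10 percentage points higher from compound 1 to compound 2 (within the scatter), so the only shift beyond the scatter in the set is the one that ends in the bromo compound.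

Compound 4 `C[C@H](NC(=O)Nc1cccc(I)c1)c1ccccc1` is the next point of the series. It differs from compound 3 by iodo in place of bromo on an aromatic carbon.

Going by the values given here, no measured step exchanges one halogen for another, so nothing speaks directly to this change. The steps that reach compound 3 are modest or within the scatter, and the bromo compound already sits near the top of the scale. On that basis the expected step in this assay from compound 3 to compound 4 is none beyond the scatter, a number 1 percentage points lower from compound 3 to compound 4 (within the scatter). Compound 4 is therefore estimated at 98%, within a range of 88% to 105%, pending the measurement.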

Compound 4, a percentage reported as activity, at one concentration (the size of the read-out at that concentration, not a potency): 93%
Estimate against measurement, compound 4: 5 percentage points above, within the range that was stated.
By their numbers in this assay, from the lowest: compounds 1, 4, 2 and 3 (each within the scatter of the next, the first and the last beyond it).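

In this assay, going by these compounds alone, the first exchange of one halogen for another at this position gives a step (a number 6 percentage points lower from compound 3 to compound 4 (within the scatter)), so iodo and bromo on this aromatic carbon cannot be told apart here. Compound 4 also cannot be separated from the ester (a number 3 percentage points lower from compound 2 to compound 4 (within the scatter)) or from the ethyl compound (a number 7 percentage points higher from compound 1 to compound 4 (within the scatter)). The one shift beyond the scatter so far (a number 13 percentage points higher from compound 1 to compound 3 (beyond the scatter)) is therefore not repeated with iodo, and the gap between ethyl and bromo now stands as a single pair rather than as a difference between halogens and ethyl, while no measurement on hand offers a reason for any of these steps.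

The compounds shown leave open whether any group at this place gives a number clearly lower than the ethyl compound, or whether the whole set simply lies near the top of the scale, and chloro, an amine, a carboxylic acid or a longer chain would test that. They also leave open whether the same exchanges behave alike when the group sits elsewhere on the ring or when the other half of the shared core changes.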